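Two Cores, One Repeated Substituent Change, One Expected Result

The compounds below may be only part of what the source reports. "The series", "measured", "known", "first", "only" and "open" are said of these compounds alone.

Of the compounds shown here, three have so far been measured in a functional assay on cells (Cancer cell lines, Homo sapiens) for inhibition; on this read-out lower numbers stand for stronger inhibition of growth and higher numbers for weaker inhibition of growth. Compound 1 `Cc1cc(-c2nc3sc(C)cn3c2/C=N/NC(=N)N)c(C)s1` gives 12000 nM. Compound 2 `Cc1cn2c(/C=N/NC(=N)N)c(-c3ccsc3)nc2s1` gives 11000 nM, and compound 3 `N=C(N)N/N=C/c1c(-c2ccsc2)nc2n1CCS2` gives 14500 nM. All three numbers lie within the usual scatter of one another, so none of them can be called more or less potent than the others.

Compound 1 and compound 2 share a core and differ in one place: 2,5-dimethylthiophen-3-yl in place of thiophen-3-yl on an aromatic carbon. That change made a 1.1-fold higher number from compound 2 to compound 1 (0.04 log units; within the scatter), a step the method cannot separate from repeat-to-repeat noise. Compound 3 is built on a different core from compound 2; the difference between the two cores is not broken down here, and their values simply sit close together.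

Compound 4 `Cc1cc(-c2nc3n(c2/C=N/NC(=N)N)CCS3)c(C)s1` has not yet been measured. Relative to compound 3 it carries the same kind of change: 2,5-dimethylthiophen-3-yl in place of thiophen-3-yl on an aromatic carbon. The surroundings are not identical word for word, since on the core of compound 3 the site also lies two ring bonds from two ring atoms that each bear a fused ring, a feature the core of compound 2 lacks, so this is the same kind of change rather than the same change.

The expectation for compound 4 rests on compound 2 and compound 1, where the step was a 1.1-fold higher number from compound 2 to compound 1 (0.04 log units; within the scatter). Compound 4 is therefore expected to show a 1.0-fold higher number from compound 3 to compound 4 (0.01 log units; within the scatter) in this assay. Compound 4 is estimated at 15000 nM, with a likely range from 7000 nM to 32000 nM.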

Compound 4, concentration for 50% growth inhibition: 24000 nM
Beside the measured number, compound 4's estimate is 1.6-fold (0.20 log units) below it; low and high end bracket the measured number.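

Replacing thiophen-3-yl with 2,5-dimethylthiophen-3-yl on the core of compound 3 gives a 1.7-fold higher number from compound 3 to compound 4 (0.22 log units; within the scatter) in this assay, so this step, like the earlier one, cannot be separated from the ordinary variation between repeated measurements. Set side by side, the two steps cannot be told apart either: the same change on two cores in this assay, a 1.1-fold higher number (0.04 log units; within the scatter) from compound 2 to compound 1 and a 1.7-fold higher number (0.22 log units; within the scatter) from compound 3 to compound 4, 1.5-fold (0.18 log units) apart, within the scatter of two such steps. This shows that the change can be carried between these two cores without any detectable difference in its outcome, but it rests on just two pairs of compounds, so it does not establish a rule for the series, nor does it show that the change has no effect at all.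

From the compounds shown here alone, both pairs test only this one replacement, so it remains open whether an amine, a carboxylic acid or a longer chain on that aromatic carbon would give a step beyond the scatter in this assay. Going by these compounds, it also remains open whether such a step, if one appeared, would carry from one core to the other as closely as this one does.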